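The compounds below may be only part of what the source reports. "The series", "measured", "known", "first", "only" and "open" are said of these compounds alone.

Compound 1, with the structure `Cc1cc(-c2nc3sc(C)cn3c2/C=N/NC(=N)N)c(C)s1`, was tested in a functional assay on cells (Cancer cell lines, Homo sapiens) for inhibition (a lower number here means a stronger inhibitor of growth, a higher number a weaker inhibitor of growth), and gave 19100 nM. Compound 2, `Cc1cn2c(/C=N/NC(=N)N)c(-c3cccs3)nc2s1`, differs from it by thiophen-2-yl in place of 2,5-dimethylthiophen-3-yl on an aromatic carbon, and in this assay compound 2 gave 12300 nM, so that the change made a 1.6-fold lower number from compound 1 to compound 2 (0.19 log units; within the scatter). Compound 3, `Cc1cc(-c2nc3n(c2/C=N/NC(=N)N)CCS3)c(C)s1`, carries a different core; how the core of compound 3 differs from the core of compound 1 is not broken down here. In this assay compound 3 gave 30900 nM, a higher number than compound 2 gave, while its value and that of compound 1 lie within the scatter of one another.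

Compound 4, `N=C(N)N/N=C/c1c(-c2cccs2)nc2n1CCS2`, has not been measured. It differs from compound 3 by thiophen-2-yl in place of 2,5-dimethylthiophen-3-yl on an aromatic carbon. Among the measured compounds shown here, this is the same kind of change as the one from compound 1 to compound 2, though not the same: on the core of compound 4 the place is also two ring bonds from two ring atoms that each bear a fused ring, which is not so on the core of compound 2. On the core of compound 1 the change gave a step within the scatter, and nothing known about the core of compound 3 says the step should be larger there, so for compound 4 a step of a 1.5-fold lower number from compound 3 to compound 4 (0.19 log units; within the scatter) is expected, resting on a 1.6-fold lower number from compound 1 to compound 2 (0.19 log units; within the scatter) and the value of compound 3. The estimate for compound 4 in this assay is thus 20000 nM, expected to fall between 8000 nM and 50000 nM.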

Compound 4, concentration for total growth inhibition: 36300 nM
For compound 4 the middle estimate is 1.8-fold (0.26 log units) below the measured one; low and high end bracket the measured number.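

In this assay, putting thiophen-2-yl in place of 2,5-dimethylthiophen-3-yl on the second core gave a 1.2-fold higher number from compound 3 to compound 4 (0.07 log units; within the scatter), so this step, like the earlier one, stays inside the usual spread of repeated measurements. Set side by side, the two steps do not differ, and the change behaves alike on the two cores as far as these numbers can tell: the same change on two cores in this assay, a 1.6-fold lower number (0.19 log units; within the scatter) from compound 1 to compound 2 and a 1.2-fold higher number (0.07 log units; within the scatter) from compound 3 to compound 4, 1.8-fold (0.26 log units) apart, within the scatter of two such steps. Among the compounds shown here, this shows that, in this small set, removing the two methyl groups from the thiophene carries from one core to the other without a step beyond the scatter, but it does not show that the group has no influence in general, that the opposite directions of the two steps are real, or that the same would hold on any further core, since each core offers only a single pair.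

The compounds shown leave open whether a different ring at this place, such as phenyl or pyridyl, or a thiophene carrying an amine or a carboxylic acid, would give a step that stands clear of the scatter. They also leave open how the numbers respond when the group of 6 heavy atoms, which all four compounds share, is replaced by a simple amide or a longer chain.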